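The source may report more compounds than this note shows. Statements on the series, on what has been measured and on what is new or still open speak of the compounds shown alone.

Series notes. Values measured in a functional assay on SMMC-7721 cells (Homo sapiens) for cytotoxicity, read by MTT assay, with a stated time of 24 h; a higher number here means a weaker inhibitor, a lower number a stronger inhibitor:

compound 1, `Cc1ccc(S(=O)(=O)N2C/C(=C\c3ccccc3F)C(=O)/C(=C/c3ccccc3F)C2)cc1`: 4100 nM
compound 2, `CC(=O)Nc1ccc(S(=O)(=O)N2C/C(=C\c3ccccc3F)C(=O)/C(=C/c3ccccc3F)C2)cc1`: 7500 nM
compound 3, `O=C1/C(=C/c2cccc(F)c2)CN(S(=O)(=O)c2ccccc2)C/C1=C\c1cccc(F)c1`: 12900 nM

Compound 3 stands with the highest number of the three, though compound 2 lies within the scatter of it; only compound 1 is separated from compound 3 by more than the scatter, with the lower number. Within the data shown here, the single one-place step among the measured compounds is a 1.8-fold higher number from compound 1 to compound 2 (0.26 log units; within the scatter), a substitution on an aromatic carbon that left the read-out essentially unchanged.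

Compound 4, `O=C1/C(=C/c2cccc(F)c2)CN(S(=O)(=O)c2ccc(O[N+](=O)[O-])cc2)C/C1=C\c1cccc(F)c1`, is not yet measured. It differs from compound 3 by nitrooxy in place of hydrogen on an aromatic carbon. Among the measured compounds shown here, no measured compound carries this group, so the step from compound 1 to compound 2 is the only guide: there, exchanging one substituent on an aromatic carbon for another produced no movement beyond the scatter. On that basis the expected step is a 1.2-fold lower number from compound 3 to compound 4 (0.07 log units; within the scatter), with no shift beyond the scatter in either direction, and the range is kept wide to allow for the absence of a direct precedent. Compound 4 is therefore expected to give 11000 nM in this assay, with an estimated range of 4000 nM to 30000 nM.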

Compound 4, half-maximal inhibitory concentration: 15300 nM
For compound 4 the middle estimate is 1.4-fold (0.14 log units) below the measured one, and the stated range covers the measured number.
By their numbers in this assay, from the lowest: compounds 1, 2, 3 and 4 (each within the scatter of the next, the first and the last beyond it).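

In this assay the change from phenyl to 4-(nitrooxy)phenyl gives a 1.2-fold higher number from compound 3 to compound 4 (0.07 log units; within the scatter) and so adds a second one-place step to the series. Unlike the earlier step, a 1.8-fold higher number from compound 1 to compound 2 (0.26 log units; within the scatter) which exchanged one substituent for another, this one starts from hydrogen and shows that an aromatic carbon para to a large group can carry nitrooxy, with its 4 heavy atoms and no ring, without a shift beyond the scatter on the core of compound 3. No measurement on hand speaks to the reason for this result.

As far as these compounds go, whether the read-out stays within the scatter with an amine, a carboxylic acid or a longer chain on this same aromatic carbon remains open, as does whether nitrooxy gives the same result on the core of compound 1. With both one-place steps within the scatter, the compounds shown do not identify any substituent at this position that moves the read-out in this assay at all.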